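Stability of a Fluoro Analogue in Human Liver Microsomes

The compounds below may be only part of what the source reports. "The series", "measured", "known", "first", "only" and "open" are said of these compounds alone.

Measured compounds:
compound 1 `C[C@H](Nc1nc(N)nc(N)c1C#N)c1c(-c2ccccc2)c(=O)n2cc(F)ccc2c1-c1ccccc1` — 98%
compound 2 `C[C@H](Nc1nc(N)nc(N)c1C#N)c1c(-c2ccccc2)c(=O)n2cc(F)ccc2c1-c1ccc(C(N)=O)cc1` — 105%

Two compounds share a common core and differ only at one aromatic carbon. In an ADME assay on microsomes from liver (Homo sapiens), read by LC-MS, using NADPH, with a stated time of 30 min, tested at 1 uM (on this read-out lower numbers stand for a less stable compound and higher numbers for a more stable compound), compound 1 gives 98%, and compound 2 gives 105%. Among the measured compounds shown here, the only step measured so far, carbamoyl in place of hydrogen on an aromatic carbon, reads a number 7 percentage points higher from compound 1 to compound 2 (within the scatter). Compound 2 thus holds the larger of the two numbers, but its step from compound 1 is within the scatter, so the two compounds cannot be told apart on this read-out.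

The unmeasured compound 3 `C[C@H](Nc1nc(N)nc(N)c1C#N)c1c(-c2ccccc2)c(=O)n2cc(F)ccc2c1-c1ccc(F)cc1` carries the change (fluoro in place of carbamoyl on an aromatic carbon), on the same aromatic carbon of a six-membered carbon ring where compound 2 carries its carbamoyl. For the measured compounds named here, only the step from compound 1 to compound 2 touches this position, and it showed no shift beyond the scatter. Going by the values given here, nothing among the measured compounds therefore points to a change in this assay for compound 3 beyond the scatter, and the expected step is a number 5 percentage points lower from compound 2 to compound 3 (within the scatter). Compound 3 is estimated at 100%, within a range from 85% to 110%.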

Compound 3, percent of the compound remaining: 87%
Compound 3: the middle estimate sits 13 percentage points above what was measured; the measured number falls inside the stated range.
By their numbers in this assay, from the lowest: compound 3; then compounds 1 and 2 (each within the scatter of the next).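

At this position, on an aromatic carbon of the six-membered ring, the group does matter in this assay: the change from 4-carbamoylphenyl to 4-fluorophenyl gives a number 18 percentage points lower from compound 2 to compound 3 (beyond the scatter), and fluoro in place of hydrogen gives a number 11 percentage points lower from compound 1 to compound 3 (beyond the scatter). Among the compounds shown here, the earlier carbamoyl-for-hydrogen step stayed within the scatter and showed no effect at this carbon, whereas fluoro is the one group of the three that sets its compound apart, with the hydrogen of compound 1 and the carbamoyl of compound 2 still not separable. The data shown offer no explanation for this difference.

With only one group giving a lower number, the compounds shown leave open whether the shift is particular to fluoro or would also appear with chloro, methoxy, an amine or a carboxylic acid on the same carbon. They also leave open whether fluoro on another carbon of this ring would give a similar step.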